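This account rests on a few compounds, and the source may have more. Where it says the series, first, only, none or still open, it means among the compounds named here.

In a functional assay on BT-549 cells (Homo sapiens) for inhibition (a higher number here means a weaker inhibitor of growth, a lower number a stronger inhibitor of growth), two compounds on a shared core have been measured so far. Compound 1 `C=C1C(=O)O[C@H]2[C@H]1CC/C(COC(=O)N1CCC(F)(F)CC1)=C\CC[C@@]1(C)O[C@@H]21` gives 2690 nM. Compound 2 `C=C1C(=O)O[C@H]2[C@H]1CC/C(COC(=O)NCCN1CCCC1)=C\CC[C@@]1(C)O[C@@H]21` gives 4750 nM. These two values lie within the scatter of each other, so compound 2 cannot be placed apart from compound 1 on these numbers.

Compound 3 `C=C1C(=O)O[C@H]2[C@H]1CC/C(COC(=O)Nc1n[nH]c(SC)n1)=C\CC[C@@]1(C)O[C@@H]21` keeps the core of compound 2 and differs in one group on an amide-type nitrogen: 5-(methylsulfanyl)-1H-1,2,4-triazol-3-yl in place of 2-(pyrrolidin-1-yl)ethyl on an amide-type nitrogen. In words, 5-(methylsulfanyl)-1H-1,2,4-triazol-3-yl stands in place of 2-(pyrrolidin-1-yl)ethyl.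

Among the measured compounds shown here, only one measured step bears on this change: a 1.8-fold higher number from compound 1 to compound 2 (0.25 log units; within the scatter). There, (2-(pyrrolidin-1-yl)ethyl)amino replaced 4,4-difluoropiperidin-1-yl on a carbonyl carbon. For the measured compounds named here, that is thin evidence, and no measured compound carries the entering group, so the data give no direction for it. A step within the scatter is therefore expected in this assay, with a wide margin on either side.

Compound 3 is estimated at 3500 nM, with an expected range from 1300 nM to 9500 nM. This estimate means an expected 1.4-fold lower number from compound 2 to compound 3 (0.13 log units; within the scatter).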

Compound 3, concentration for 50% growth inhibition: 1470 nM
For compound 3 the middle estimate is 2.4-fold (0.38 log units) above the measured one, within the range that was stated.
By their numbers in this assay, from the lowest: compounds 3, 1 and 2 (each within the scatter of the next, the first and the last beyond it).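

In this assay, among the compounds shown here, 5-(methylsulfanyl)-1H-1,2,4-triazol-3-yl in place of 2-(pyrrolidin-1-yl)ethyl on an amide-type nitrogen gives a 3.2-fold lower number from compound 2 to compound 3 (0.51 log units; beyond the scatter), the first step to pass the scatter, so this position does respond to the group it carries, even with the heavy-atom count unchanged and a five-membered aromatic ring standing for a five-membered non-aromatic one. The step against the carbamate-type group of compound 1, (5-(methylsulfanyl)-1H-1,2,4-triazol-3-yl)amino in place of 4,4-difluoropiperidin-1-yl on a carbonyl carbon, is a 1.8-fold lower number from compound 1 to compound 3 (0.26 log units; within the scatter), so compound 3 stands apart from compound 2 alone and cannot be called the strongest of the three. Nothing measured here accounts for the step from compound 2 to compound 3.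

The compounds shown leave open whether the five-membered aromatic ring or its methylsulfanyl group carries the step, a question that a methyl, an amino group or a plain hydrogen in place of methylsulfanyl would address. As far as these compounds go, it also remains open how a carboxylic acid or a longer chain on the same amide-type nitrogen would read in this assay.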